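Swapping the benzyl ring substituent on a sulfur-linked chain

The source may report more compounds than this note shows. Statements on the series, on what has been measured and on what is new or still open speak of the compounds shown alone.

Of the compounds shown here, three sharing one core have been tested in a functional assay on HCT-116 cells (Homo sapiens) for cytotoxicity, read by MTT assay, with a stated time of 72 h; a lower number here means a stronger inhibitor, a higher number a weaker inhibitor. Compound 1 `Cc1cc(S(=O)(=O)/N=C(\N)n2nccc2-c2ccccc2)c(SCc2ccccc2)cc1Cl` gives 12000 nM in this assay. Compound 2 `Cc1cc(S(=O)(=O)/N=C(\N)n2nccc2-c2ccccc2)c(SCc2cccc3ccccc23)cc1Cl`, which carries a naphthalen-1-yl in place of the phenyl on the saturated chain carbon bound to a sulfur, gives 7000 nM; the step of a 1.7-fold lower number from compound 1 to compound 2 (0.23 log units; within the scatter) is within the scatter. Compound 3 `Cc1cc(S(=O)(=O)/N=C(\N)n2nccc2-c2ccccc2)c(SCc2cccc(C(F)(F)F)c2)cc1Cl` gives 14000 nM; among the three numbers it stands highest, yet the steps of a 1.2-fold higher number from compound 1 to compound 3 (0.07 log units; within the scatter) and a 2.0-fold higher number from compound 2 to compound 3 (0.30 log units; within the scatter) both fall within the scatter, so no ordering among the three can be claimed.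

Compound 4 `Cc1cc(S(=O)(=O)/N=C(\N)n2nccc2-c2ccccc2)c(SCc2ccc(Cl)cc2)cc1Cl` has not yet been measured in this assay. It differs from compound 3 in one place: 4-chlorophenyl in place of 3-(trifluoromethyl)phenyl on a saturated chain carbon bound to a sulfur.

Going by the values given here, two measured steps bear on this change, since each also varies the ring on the saturated chain carbon bound to a sulfur: from compound 1 to compound 2 and from compound 2 to compound 3. Neither moved the number beyond the scatter, and the change from compound 1 to compound 3 likewise stayed within it. The step of a 1.2-fold lower number from compound 3 to compound 4 (0.07 log units; within the scatter) is therefore expected to be no larger than the scatter, in no firm direction. Compound 4 is estimated to give 12000 nM in this assay, between 6000 nM and 24000 nM.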

Compound 4, half-maximal inhibitory concentration: 7000 nM
Compound 4: middle estimate off by 1.7-fold (0.23 log units), on the high side; the range from low to high includes it.
By their numbers in this assay, from the lowest: compounds 2, 4, 1 and 3 (each within the scatter of the next).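

In this assay, the 4-chlorophenyl ring adds three steps, a 2.0-fold lower number from compound 3 to compound 4 (0.30 log units; within the scatter), no change at the digits printed from compound 2 to compound 4 (within the scatter) and a 1.7-fold lower number from compound 1 to compound 4 (0.23 log units; within the scatter), and none goes beyond the scatter. A chloro placed directly on the aromatic ring therefore joins naphthalen-1-yl and 3-(trifluoromethyl)phenyl: among these four compounds, every step at this position on the saturated chain carbon bound to a sulfur stays within the scatter, so the four rings cannot be ranked here, even though the ring groups differ in size and in the atoms they carry. No measurement shown here explains why these rings give such similar numbers.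

From the compounds shown here alone, all four groups are still carbon-only aromatic rings with no hydrogen-bond donors or acceptors, so it remains open whether a ring carrying an amine or a carboxylic acid would move the number beyond the scatter. A longer chain on the sulfur, or a saturated ring such as cyclohexyl in place of the aromatic one, also remains an open case for this position.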